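A few compounds are considered here, and "the series" means these few. Any claim that something is new, unique, unknown or untested is made for them only; others in the source may bear on it.

Compound 1 `CC(O)(COc1cccc(C(F)(F)F)c1)C(=O)Nc1ccc(S(F)(F)(F)(F)F)cc1`: 21900 nM
Compound 2 `CC(O)(COc1cc(C(F)(F)F)cc(C(F)(F)F)c1)C(=O)Nc1ccc(S(F)(F)(F)(F)F)cc1`: 8600 nM
Compound 3 `CC(O)(COc1cccc(C(F)(F)F)c1)C(=O)Nc1cccc(S(F)(F)(F)(F)F)c1`: 31700 nM

All three were tested in a functional assay on DU-145 cells (Homo sapiens) for antiproliferative activity, read by propidium iodide staining, with a stated time of 96 h; on this read-out higher numbers stand for weaker inhibition and lower numbers for stronger inhibition. In this assay compound 1 gives 21900 nM, compound 2 gives 8600 nM, and compound 3 gives 31700 nM. Compound 1 and compound 3 are built from the same atoms joined differently; the difference between the two cores is not broken down here, and their two values lie within the scatter of each other. From compound 1 to compound 2 the change is trifluoromethyl in place of hydrogen on an aromatic carbon, and the step it made was a 2.5-fold lower number from compound 1 to compound 2 (0.41 log units; beyond the scatter).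

Compound 4 `CC(O)(COc1cc(C(F)(F)F)cc(C(F)(F)F)c1)C(=O)Nc1cccc(S(F)(F)(F)(F)F)c1` has not yet been measured. It differs from compound 3 by trifluoromethyl in place of hydrogen on an aromatic carbon, the same change, at a place described in the same words. For the measured compounds named here, since the only earlier example of this change gave a 2.5-fold lower number from compound 1 to compound 2 (0.41 log units; beyond the scatter), a step of similar size is expected. The expected step is a 2.5-fold lower number from compound 3 to compound 4 (0.40 log units; beyond the scatter). Compound 4 is therefore estimated at 12700 nM in this assay. For compound 4 the expected span runs from 6000 nM to 28000 nM, kept wide because a single pair is the only basis.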

Compound 4, half-maximal inhibitory concentration: 9300 nM
Compound 4: middle estimate off by 1.4-fold (0.14 log units), on the high side; the range from low to high includes it.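

In this assay, trifluoromethyl in place of hydrogen on an aromatic carbon lowered the number on the second core as well, giving a 3.4-fold lower number from compound 3 to compound 4 (0.53 log units; beyond the scatter). In this small series, the change therefore carried from one core to the other with its direction kept and with no size difference that can be told apart from scatter: the same change on two cores in this assay, a 2.5-fold lower number (0.41 log units; beyond the scatter) from compound 1 to compound 2 and a 3.4-fold lower number (0.53 log units; beyond the scatter) from compound 3 to compound 4, 1.3-fold (0.13 log units) apart, within the scatter of two such steps

For the compounds shown here, this agreement rests on only two pairs, on two cores and in a single assay, so it does not show that the step would hold on a core outside these four compounds, and it says nothing about why the number falls.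

The compounds shown carry only hydrogen or trifluoromethyl at this place, so it stays open whether a nitrile, a chlorine atom or an amine there would move the number in the same way. Also open, on these data alone, is whether the step would persist on a core in which a methyl group replaces the amide hydrogen.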